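The source may hold more compounds than are shown below. What is called first, only, known or untested is meant among the compounds shown, and "the series" means these compounds.

Measured so far in a functional assay on MCF7 cells (Homo sapiens) for inhibition, with a stated time of 48 h; on this read-out higher numbers stand for weaker inhibition and lower numbers for stronger inhibition:
- compound 1 `COc1cc(Sc2c[nH]c3ccc([N+](=O)[O-])cc23)cc(OC)c1OC` gives 560 nM
- compound 2 `COc1cc(Sc2c[nH]c3ccc(N)cc23)cc(OC)c1OC` gives 260 nM
- compound 3 `COc1cc(Sc2c[nH]c3ccc(OC(C)C)cc23)cc(OC)c1OC` gives 1500 nM

Compound 3, at 1500 nM (the highest number of the three), is the weakest inhibitor so far. The next compound, compound 4 `COc1cc(Sc2c[nH]c3ccc(O)cc23)cc(OC)c1OC`, replaces isopropoxy with hydroxy, which puts hydrogen in place of isopropyl on an oxygen on an aromatic ring.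

Going by the values given here, two measured steps bear on this change. Putting isopropoxy in place of amino gave a 5.8-fold higher number from compound 2 to compound 3 (0.76 log units; beyond the scatter) and putting isopropoxy in place of nitro gave a 2.7-fold higher number from compound 1 to compound 3 (0.43 log units; beyond the scatter) in the same read-out. Both moved to a higher number. Hydroxy itself has not been tested, so the comparison is loose, and amino serves here as its nearest measured stand-in.

Losing the isopropyl is therefore expected to give a modest move to a lower number, an estimated 3.3-fold lower number from compound 3 to compound 4 (0.52 log units; beyond the scatter) in this assay. For compound 4 the expected value is 450 nM within an estimated range of 150 nM to 1300 nM in this read-out.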

Compound 4, half-maximal inhibitory concentration: 190 nM
For compound 4 the middle estimate is 2.4-fold (0.37 log units) above the measured one; the range from low to high includes it.
By their numbers in this assay, from the lowest: compounds 4 and 2 (each within the scatter of the next); then compound 1; then compound 3.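

On the oxygen on the aromatic ring, taking away the isopropyl to leave hydroxy gives (a 7.9-fold lower number from compound 3 to compound 4 (0.90 log units; beyond the scatter)) in this assay, so the isopropyl group itself, and not the oxygen it sits on, goes with the high number of compound 3. Hydroxy and amino are not separated at this position (a 1.4-fold lower number from compound 2 to compound 4 (0.14 log units; within the scatter)), while hydroxy stands clearly apart from nitro (a 2.9-fold lower number from compound 1 to compound 4 (0.47 log units; beyond the scatter)), so two different groups here give numbers within the usual scatter of each other. Nothing measured alongside these numbers explains the differences.

The compounds shown leave open whether methoxy, a shorter chain on the same oxygen, would read like hydroxy or like isopropoxy. They also leave open how a carboxylic acid or an acetamide would read at this position.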